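Cytotoxicity notes on the benzyl arm of the series

This account rests on a few compounds, and the source may have more. Where it says the series, first, only, none or still open, it means among the compounds named here.

The series is followed in a toxicity assay on NIH3T3 cells (Mus musculus) for cytotoxicity, read by resazurin assay; a lower number here means that less compound is needed, a higher number that more compound is needed for the effect. Compound 1, `c1ccc(Cn2cncc2CNc2cccc(-c3ccccc3)c2)cc1`, is reported only as a limit of that assay and not as a number, namely > 750 nM; this is the limit of > 750 nM in this assay, at which 1 of the 2 values shown sits. Within the data shown here, compound 2, `COC(=O)c1ccc(NCc2cncn2Cc2ccc(C)cc2)cc1-c1ccccc1`, gives 50000 nM in this assay, which is the only numeric value shown for it, so compound 2 stands alone on the numbers. Among the measured compounds shown here, no step between two measured compounds is available, and nothing sets a measured scale for a change of this kind. Compound 3, `COC(=O)c1ccc(NCc2cncn2Cc2ccc(Br)cc2)cc1-c1ccccc1`, is not yet measured and differs from compound 2 by bromo in place of methyl on an aromatic carbon. For compound 3 the expected step is a 1.3-fold lower number from compound 2 to compound 3 (0.10 log units; within the scatter), estimated to stay within the usual scatter of this assay rather than to move in either direction. Compound 3 is accordingly estimated at 40000 nM, with a range from 15000 nM to 120000 nM.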

Compound 3, half-maximal effective concentration: > 10000 nM
Compound 3: no number, only a limit (the forecaster's own chance of this, stated with the estimate: 20%); the middle value does not contradict the limit.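

In this assay compound 3 is reported only as a limit, > 10000 nM, so the step from compound 2 to compound 3 cannot be read. The compounds shown leave open whether bromo in place of methyl on the benzyl arm changes the number at all.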